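From dimethylamino to piperidin-1-yl on a shared core

The source may hold more compounds than are shown below. What is called first, only, known or untested is meant among the compounds shown, and "the series" means these compounds.

- Compound 1 `Cc1ccc2nc(SCc3cc([N+](=O)[O-])cc([N+](=O)[O-])c3)[nH]c(=O)c2c1`: > 64000 nM
- Compound 2 `CN(C)c1ccc2nc(SCc3cc([N+](=O)[O-])cc([N+](=O)[O-])c3)[nH]c(=O)c2c1`: 14000 nM

In an ADME assay on MRC5 cells (Homo sapiens) for cytotoxicity, read by neutral red uptake (on this read-out higher numbers stand for lower toxicity in this test and lower numbers for higher toxicity in this test), compound 1 reads > 64000 nM, which is a limit of the assay and not a number. Within the data shown here, compound 2 gives 14000 nM, the only actual number so far.

Compound 3 `O=c1[nH]c(SCc2cc([N+](=O)[O-])cc([N+](=O)[O-])c2)nc2ccc(N3CCCCC3)cc12` has not yet been measured. It carries piperidin-1-yl in place of dimethylamino on an aromatic carbon of the shared core: piperidin-1-yl in place of dimethylamino on an aromatic carbon.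

Among the measured compounds shown here, only one measured step bears on this change: an at least 4.5-fold lower number from compound 1 to compound 2 (0.66 log units; beyond the scatter). That step starts from the limit of > 64000 nM in this assay, at which 1 of the 2 values shown sits, so its size is known only from one side. It compares methyl with dimethylamino, and it therefore gives only a loose guide to replacing dimethylamino with piperidin-1-yl. Compound 3 is thus expected to stay close to compound 2, with no step beyond the scatter expected in this assay. The expected step is a 1.2-fold lower number from compound 2 to compound 3 (0.07 log units; within the scatter). For compound 3 the estimated value is 12000 nM, with an expected range from 4500 nM to 35000 nM.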

Compound 3, half-maximal cytotoxic concentration: > 64000 nM
Compound 3: no number, only a limit (the forecaster's own chance of this, stated with the estimate: 10%); middle value at least 5.3-fold (0.72 log units) from the limit.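

In this assay, a nitrogen attached at this aromatic carbon of the shared core is not enough by itself to give the lower number of compound 2: closing the dimethylamino group's two carbons into the larger piperidin-1-yl ring brings an at least 4.5-fold higher number from compound 2 to compound 3 (0.66 log units; beyond the scatter). Compound 3 reads > 64000 nM, which is a limit of the assay and not a number. Compound 1 and compound 3 both end at a limit, so the step between them cannot be read, and the new step is known from one side only: the limit of > 64000 nM in this assay, at which 2 of the 3 values shown sit.

Among the three compounds, only the dimethylamino compound gives an actual number, and a single comparison cannot show whether that lower number is particular to dimethylamino or shared by other groups attached through nitrogen, such as diethylamino, pyrrolidin-1-yl or morpholin-4-yl. From the compounds shown here alone, how the methyl and piperidin-1-yl compounds differ from each other also stays open, as does whether the same change would behave alike at another carbon of the shared core.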